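Thioester in place of amide on the shared core

A few compounds are considered here, and "the series" means these few. Any claim that something is new, unique, unknown or untested is made for them only; others in the source may bear on it.

Measured so far in an assay on membranes from HeLa cells for displacement of a labelled ligand from adenosine receptor A3 (Homo sapiens), read by scintillation counting, with a stated time of 180 min, tested at 1 uM; on this read-out higher numbers stand for more inhibition at the one concentration tested (going by the name of the read-out) and lower numbers for less inhibition:
compound 1 `CCCC(=O)C1=C(C)NC(=O)NC1c1ccco1`, 1%
compound 2 `CC1=C(C(=O)CC(C)C)C(c2ccco2)NC(=O)N1`, 31%
compound 3 `CC1=C(C(=O)NC(C)C)C(c2ccco2)NC(=O)N1`, 4%

Compound 3 stands second of the three, close to compound 1 and well under compound 2. The step to compound 4 `CCSC(=O)C1=C(C)NC(=O)NC1c1ccco1` is ethylsulfanyl in place of isopropylamino on a carbonyl carbon. Within the data shown here, two measured steps touch the same carbonyl carbon: a number 3 percentage points higher from compound 1 to compound 3 (within the scatter), and a number 27 percentage points lower from compound 2 to compound 3 (beyond the scatter). Only the isobutyl chain of compound 2 gave a number beyond the scatter; propyl and isopropylamino sit together at the bottom. Ethylsulfanyl is a third group at this carbon with no measured precedent, so the expectation for compound 4 is a step of a number 2 percentage points higher from compound 3 to compound 4 (within the scatter), within the scatter. Compound 4 is therefore estimated at 6%, range 0% to 22%.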

Compound 4, a percentage reported as inhibition, at one concentration (the size of the read-out at that concentration, not a potency): 14%
Estimate against measurement, compound 4: 8 percentage points below, within the range that was stated.
By their numbers in this assay, from the lowest: compounds 1, 3 and 4 (each within the scatter of the next, the first and the last beyond it); then compound 2.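

Ethylsulfanyl on the carbonyl carbon cannot be told apart from isopropylamino in this assay (a number 10 percentage points higher from compound 3 to compound 4 (within the scatter)), yet it is separated from propyl (a number 13 percentage points higher from compound 1 to compound 4 (beyond the scatter)), even though propyl and isopropylamino are not separated from each other. Isobutyl keeps the highest number at this carbon (a number 17 percentage points lower from compound 2 to compound 4 (beyond the scatter)), so the thioester does not reach the level of that chain. Nothing available explains these differences.

Still open, from the compounds shown here alone, is whether an ethoxy group, giving the ester, reads like ethylsulfanyl. Also open, going by these compounds, is whether a longer branched chain than isobutyl raises the number further.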